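Nitro Removal on Two Cores: What to Expect

A few compounds are considered here, and "the series" means these few. Any claim that something is new, unique, unknown or untested is made for them only; others in the source may bear on it.

Compound 1, `COc1ccc(-c2cc(=O)c3c(OC)cc(OC)cc3n2S(=O)(=O)c2ccc(C)c([N+](=O)[O-])c2)cc1`, in a functional assay on KOPN-8 cells (Homo sapiens) for antiproliferative activity, with a stated time of 72 h (on this read-out lower numbers stand for an effect already at smaller amounts and higher numbers for an effect only at larger amounts of compound), gives > 51700 nM, which is a limit of the assay and not a number.
Compound 2, `COc1ccc(-c2cc(=O)c3c(OC)cc(OC)cc3n2S(=O)(=O)c2ccc(C)cc2)cc1`, in this assay gives > 44800 nM, likewise a limit.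
Compound 3, `COC(=O)c1cc(=O)c2cc(NC(=O)Nc3ccc(C(F)(F)F)cc3[N+](=O)[O-])ccc2[nH]1`, in this assay gives > 25900 nM, again a limit.

Compounds 1 and 2 share one core and differ by hydrogen in place of nitro on an aromatic carbon. The step that the two limits leave unreadable from compound 1 to compound 2 cannot be sized, because both ends sit at limits, the limit of > 51700 nM in this assay, at which 1 of the 3 values shown sits, and (the limit of > 44800 nM in this assay, at which 1 of the 3 values shown sits). Compound 3 rests on a different core, and the difference between the two cores is not broken down here. For compound 3 only a limit is known, (the limit of > 25900 nM in this assay, at which 1 of the 3 values shown sits).

Compound 4, `COC(=O)c1cc(=O)c2cc(NC(=O)Nc3ccc(C(F)(F)F)cc3)ccc2[nH]1`, is not yet measured and differs from compound 3 by hydrogen in place of nitro on an aromatic carbon. This is the same kind of change as that between compounds 1 and 2, though not the same: in compound 1 the nitro sits ortho to a methyl group and meta to a large group, whereas in compound 3 it sits ortho to a large group and meta to a trifluoromethyl group. The step from compound 3 to compound 4 is expected to be about a step that the limit leaves unreadable from compound 3 to compound 4, an expectation that rests only on the unreadable a step that the two limits leave unreadable from compound 1 to compound 2, which gives no sign that removing the nitro brings a measurable effect within range. Compound 4 is therefore estimated at 30000 nM in this assay, plausibly between 8000 nM and 100000 nM, and most likely the assay will again report only a limit.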

Compound 4, half-maximal effective concentration: > 6350 nM
Compound 4 ended at the assay's limit; the forecaster's own chance of this, stated with the estimate: 70%; the middle value is on the limit's open side.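

In this assay compound 4 gives > 6350 nM, which is a limit of the assay and not a number. Compound 3 also stands at a limit, so no step can be read between compound 3 and compound 4. The compounds shown leave open whether hydrogen in place of nitro changes the read-out on either core, and at what concentration any of the four compounds would reach a half-maximal effect.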